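The source may hold more compounds than are shown below. What is called first, only, known or untested is meant among the compounds shown, and "the series" means these compounds.

Measured so far:
Compound 1 `Cc1cc(O)c(C2=NN(c3ccc(S(N)(=O)=O)cc3)C(c3ccccc3O)C2)cc1Cl` gives 1600 nM in a functional assay on SF-539 cells (Homo sapiens) for antiproliferative activity, with a stated time of 48 h; a lower number here means a stronger inhibitor of growth, a higher number a weaker inhibitor of growth.
Compound 2 `Cc1cc(O)c(C2=NN(c3ccc(S(N)(=O)=O)cc3)C(c3ccccc3Cl)C2)cc1Cl` gives 1790 nM in this assay.

Compound 2 has the higher of the two numbers, but its nearest neighbour, compound 1, differs from it only within the scatter, so the two compounds stand together rather than apart. Among the compounds with values here, the single measured step, a 1.1-fold higher number from compound 1 to compound 2 (0.05 log units; within the scatter), is chloro in place of hydroxy on an aromatic carbon, and it leaves the number essentially where it was.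

The new compound 3 `COc1ccc(C2CC(c3cc(Cl)c(C)cc3O)=NN2c2ccc(S(N)(=O)=O)cc2)c(OC)c1OC` alters that same part of the molecule far more deeply: 2,3,4-trimethoxyphenyl in place of 2-chlorophenyl on a saturated ring carbon. The earlier step bears on compound 3 only in showing that one exchange at this aromatic ring passed without a shift beyond the scatter; it says nothing about exchanging the whole ring for one bearing three methoxy groups. Within the data shown here, no other measured step touches this change. With so little to go on, compound 3 is expected to stay near compound 2, and the expected step of a 1.2-fold lower number from compound 2 to compound 3 (0.08 log units; within the scatter) is taken as within the scatter, with a wide range allowing for a real shift either way. The estimate for compound 3 in this assay is 1500 nM, between 400 nM and 6000 nM.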

Compound 3, concentration for 50% growth inhibition: 1770 nM
For compound 3 the middle estimate is 1.2-fold (0.07 log units) below the measured one; the measured number falls inside the stated range.
By their numbers in this assay, from the lowest: compounds 1, 3 and 2 (each within the scatter of the next).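

In this assay, putting 2,3,4-trimethoxyphenyl in place of 2-chlorophenyl on the saturated ring carbon gives a 1.0-fold lower number from compound 2 to compound 3 (0.00 log units; within the scatter), and putting it in place of 2-hydroxyphenyl gives a 1.1-fold higher number from compound 1 to compound 3 (0.04 log units; within the scatter). The earlier compounds showed only one substituent exchanged on this aromatic ring, whereas compound 3 shows that, among these three compounds, a larger group with three methoxy groups and 3 hydrogen-bond acceptors can stand at this position, and the growth-inhibition number stays within the scatter of the other two. Nothing available here accounts for why the number is so insensitive to this change.

From the compounds shown here alone, all three compounds carry a substituted phenyl ring at this position, so it remains open whether a carboxylic acid or an amine on that ring, or a cyclohexyl ring in its place, would leave the number equally undisturbed. Going by these compounds, the 4-sulfamoylphenyl and 5-chloro-2-hydroxy-4-methylphenyl groups are the same in all three compounds, so what happens when either of them is exchanged also remains open.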